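The source may report more compounds than this note shows. Statements on the series, on what has been measured and on what is new or still open speak of the compounds shown alone.

In a functional assay on HCC827 cells (Homo sapiens) for antiproliferative activity, read by MTT assay, with a stated time of 72 h (a higher number here means a weaker inhibitor, a lower number a stronger inhibitor), compound 1 `CN1CCN(c2ccc(Nc3ncc4nc([S+]([O-])Cc5cccnc5)n(C5CCOCC5)c4n3)cc2)CC1` gives > 10000 nM, which is a limit of the assay and not a number. Compound 2 `CN1CCN(c2ccc(Nc3ncc4nc([S+]([O-])Cc5cccnc5)n(C5CCCC5)c4n3)cc2)CC1` gives 2350 nM, and compound 3 `CN1CCN(c2ccc(Nc3ncc4nc(Sc5ccccc5)n([C@H]5CC[C@H](O)CC5)c4n3)cc2)CC1` gives 42.6 nM. The next compound, compound 4 `CN1CCN(c2ccc(Nc3ncc4nc([S+]([O-])c5ccccc5)n(C5CCOCC5)c4n3)cc2)CC1`, keeps the oxan-4-yl group of compound 1 and has phenyl in place of (pyridin-3-yl)methyl on a sulfur.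

Within the data shown here, no measured step changes the group on that sulfur. Among the measured compounds shown here, the only measured step, an at least 4.2-fold lower number from compound 1 to compound 2 (0.62 log units; beyond the scatter), swaps the group on an aromatic nitrogen instead, so it bears on this change only indirectly, showing that one substitution can bring a number into the measurable range. Compound 3 also has phenyl on a sulfur and gives 42.6 nM, but it differs from compound 4 elsewhere as well, which makes it only a loose guide. A modest move toward a lower number is therefore expected, though a second limit remains possible. The expected change is an at least 3.3-fold lower number from compound 1 to compound 4 (0.52 log units; beyond the scatter). For compound 4, the estimated value is 3000 nM, with an expected range from 600 nM to 10000 nM.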

Compound 4, half-maximal inhibitory concentration: 411 nM
Estimate against measurement, compound 4: 7.3-fold (0.86 log units) above; measured number outside the range, below it.
By their numbers in this assay, from the lowest: compound 3; then compound 4; then compound 2. At a limit, above all of these: compound 1.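

Among these compounds, this is the first change at the sulfur that can be read, and in this assay it gives an at least 24-fold lower number from compound 1 to compound 4 (1.38 log units; beyond the scatter), so the group on that sulfur alone brings a compound with the oxan-4-yl group into the measurable range. Compound 1 gives > 10000 nM, which is a limit of the assay and not a number. The step therefore sets only a minimum size, and its true size stays unknown: the limit of > 10000 nM in this assay, at which 1 of the 4 values shown sits.

The change swaps a pyridine ring for a carbon-only ring and also removes the methyl link, and the compounds shown do not separate these two differences. A benzyl group or a plain pyridin-3-yl group on that sulfur would tell them apart, while a cyclopentyl group on the aromatic nitrogen together with phenyl on the sulfur would show whether the two changes add up.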